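Chain Extension Toward Compound 4 and Expected Cytotoxicity

This account rests on a few compounds, and the source may have more. Where it says the series, first, only, none or still open, it means among the compounds named here.

The study reports three measured compounds and one that remains to be measured. Compound 1 `Cc1ncc([N+](=O)[O-])n1CCCCCCBr` gives 69.9 ug/mL in an ADME assay on J774 cells (Mus musculus) for cytotoxicity, read by resazurin assay, with a stated time of 24 h; a lower number here means a stronger inhibitor, a higher number a weaker inhibitor. Compound 2 `Cc1ncc([N+](=O)[O-])n1CCCN1CCCCC1` reaches only a limit of the assay in this assay, recorded as > 100 ug/mL. The step of an at least 1.4-fold higher number from compound 1 to compound 2 (0.15 log units; that floor lies within the scatter) is therefore a lower bound on the change. Compound 3 `Cc1ncc([N+](=O)[O-])n1CCCN1CCN(c2ccnc3cc(Cl)ccc23)CC1` likewise sits at a limit in this assay, reported as > 100 ug/mL. Its standing is known only as a limit, which it shares with one other value, as the limit of > 100 ug/mL in this assay, at which 2 of the 3 values shown sit, records.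

Compound 4 `Cc1ncc([N+](=O)[O-])n1CCCCN1CCN(c2ccnc3cc(Cl)ccc23)CC1` differs from compound 3 by (2-methyl-5-nitro-1H-imidazol-1-yl)methyl in place of 2-methyl-5-nitro-1H-imidazol-1-yl on a saturated chain carbon, three bonds along the chain from an amine nitrogen in a ring. Among the measured compounds shown here, no measured step alters a chain in this way; the only measured step, an at least 1.4-fold higher number from compound 1 to compound 2 (0.15 log units; that floor lies within the scatter), concerns a different place and itself lies within the scatter at its floor. Because compound 3 already stands at the limit > 100 ug/mL, the change in chain length is not expected to move the value beyond the scatter in this assay. Compound 4 is therefore expected to give 150 ug/mL, between 70 ug/mL and 400 ug/mL. The expected step that the limit leaves unreadable from compound 3 to compound 4 is essentially none, and compound 4 would most likely be reported only as a limit.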

Compound 4, half-maximal inhibitory concentration: > 100 ug/mL
Compound 4: only a limit was reported; the forecaster's own chance of this, stated with the estimate: 75%; the middle value does not contradict the limit.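

In this assay compound 4 is recorded only as a limit, > 100 ug/mL. Compound 3 also stands at a limit, so no step can be read between compound 3 and compound 4: the limit of > 100 ug/mL in this assay, at which 3 of the 4 values shown sit. The compounds shown leave open whether (2-methyl-5-nitro-1H-imidazol-1-yl)methyl in place of 2-methyl-5-nitro-1H-imidazol-1-yl changes the value at all.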